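Compound 3: methyl in place of chloro

This account rests on a few compounds, and the source may have more. Where it says the series, first, only, none or still open, it means among the compounds named here.

Values in a functional assay on DU-145 cells (Homo sapiens) for inhibition, read by MTT assay, with a stated time of 72 h (a lower number here means a stronger inhibitor, a higher number a weaker inhibitor), so far
- compound 1 `Cc1ccccc1N1CCN(C2=CC(=O)c3ccccc3C2=O)CC1` gives 5700 nM
- compound 2 `O=C1C=C(N2CCN(c3ccc(F)cc3)CC2)C(=O)c2c(O)cccc21` gives 8400 nM
- compound 3 `O=C1C=C(N2CCN(c3ccccc3Cl)CC2)C(=O)c2c(O)cccc21` gives 2300 nM

Compound 3 holds the lowest number of the three, with compound 1 and compound 2 both higher beyond the scatter. Next comes compound 4 `Cc1ccccc1N1CCN(C2=CC(=O)c3cccc(O)c3C2=O)CC1` with methyl in place of chloro on an aromatic carbon. For the measured compounds named here, the one measured step that bears on this is a 3.7-fold lower number from compound 2 to compound 3 (0.56 log units; beyond the scatter) and it was modest. It is a different exchange, so it offers only a rough scale. In this assay a small step toward a higher number is expected, no larger than that one. Going by the values given here, the estimated move is a 1.4-fold higher number from compound 3 to compound 4 (0.14 log units; within the scatter) and no measurement yet tests it. Compound 4 is expected at 3200 nM with an estimated range (1300 nM to 7000 nM).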

Compound 4, half-maximal inhibitory concentration: 2300 nM
For compound 4 the middle estimate is 1.4-fold (0.14 log units) above the measured one; the measured number falls inside the stated range.
By their numbers in this assay, from the lowest: compounds 3 and 4 (each within the scatter of the next); then compounds 1 and 2 (each within the scatter of the next).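

In this assay the 2-chlorophenyl to 2-methylphenyl exchange gives no change at the digits printed from compound 3 to compound 4 (within the scatter), so chloro and methyl are not told apart at this place, ortho to a large group. Hydroxy in place of hydrogen on an aromatic carbon gives a 2.5-fold lower number from compound 1 to compound 4 (0.39 log units; beyond the scatter), the only reading of that hydroxy so far, and 2-methylphenyl in place of 4-fluorophenyl gives a 3.7-fold lower number from compound 2 to compound 4 (0.56 log units; beyond the scatter), the same size as the step to the 2-chlorophenyl compound. No supporting data bear on why these values fall as they do.

From the compounds shown here alone, whether methoxy, trifluoromethyl or an amine at this place would separate from chloro and methyl remains open. Also open, going by these compounds, is whether the hydroxy step holds with other aryl groups on the ring amine.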